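Fluoro on the terminal phenyl: thiourea and guanidine analogues

This account rests on a few compounds, and the source may have more. Where it says the series, first, only, none or still open, it means among the compounds named here.

Measured so far:
compound 1 `CN(c1cc2ncc(=O)[nH]c2cc1NC(=S)Nc1ccccc1)C1CCCCC1`: 49600 nM
compound 2 `CN(c1cc2ncc(=O)[nH]c2cc1NC(=S)Nc1ccc(F)cc1)C1CCCCC1`: 64300 nM
compound 3 `CN(c1cc2ncc(=O)[nH]c2cc1NC(=N)NCc1ccccc1)C1CCCCC1`: 9940 nM

In an ADME assay on Huh-7 cells (Homo sapiens) for cytotoxicity (on this read-out lower numbers stand for stronger inhibition and higher numbers for weaker inhibition), compound 1 gives 49600 nM and compound 2 gives 64300 nM. The change between them is fluoro in place of hydrogen on an aromatic carbon and the step is a 1.3-fold higher number from compound 1 to compound 2 (0.11 log units; within the scatter). Compound 3 gives 9940 nM in this assay; its core differs from that of compound 1 by a group of 10 heavy atoms (8 carbon, 2 nitrogen; one six-membered aromatic ring of carbon only) in place of a group of 9 heavy atoms (7 carbon, 1 nitrogen, 1 sulfur; one six-membered aromatic ring of carbon only), on a nitrogen on an aromatic ring, with the step of a 5.0-fold lower number from compound 1 to compound 3 (0.70 log units; beyond the scatter). From compound 2 the step is a 6.5-fold lower number from compound 2 to compound 3 (0.81 log units; beyond the scatter).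

Compound 4 `CN(c1cc2ncc(=O)[nH]c2cc1NC(=N)NCc1ccc(F)cc1)C1CCCCC1` has not yet been measured. It differs from compound 3 by fluoro in place of hydrogen on an aromatic carbon. The place of this change reads the same as for the pair of compound 1 and compound 2, so it is the same change, set on the core of compound 3 rather than on that of compound 1.

Among the measured compounds shown here, the step from compound 3 to compound 4 in this assay is expected to be a 1.3-fold higher number from compound 3 to compound 4 (0.10 log units; within the scatter), beside the earlier one of a 1.3-fold higher number from compound 1 to compound 2 (0.11 log units; within the scatter); this rests on the one measured pair alone, and the step there was within the scatter. Compound 4 is therefore estimated at 12500 nM, expected to lie between 5000 nM and 32000 nM.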

Compound 4, half-maximal inhibitory concentration: 10200 nM
Estimate against measurement, compound 4: 1.2-fold (0.09 log units) above; low and high end bracket the measured number.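

In this assay the fluoro change on the core of compound 3 gives a 1.0-fold higher number from compound 3 to compound 4 (0.01 log units; within the scatter), and compound 4 cannot be told apart from compound 3. Set beside the earlier step, the change reads alike on the two cores: the same change on two cores in this assay, a 1.3-fold higher number (0.11 log units; within the scatter) from compound 1 to compound 2 and a 1.0-fold higher number (0.01 log units; within the scatter) from compound 3 to compound 4, 1.3-fold (0.10 log units) apart, within the scatter of two such steps

Among the compounds shown here, this shows only that a step within the scatter on one core stayed within the scatter on the other; it does not show a real fluoro effect carried across, as neither step stands clear of the scatter, and two pairs say nothing about cores beyond these two.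

Left open is whether another group on the same aromatic carbon, such as chloro, methoxy or trifluoromethyl, would move the number beyond the scatter on either core. Also open, as far as these compounds go, is how a longer chain in place of benzyl, or an amine on the terminal ring, would read in this assay.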